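Swapping Amino for Methoxy: an Expected Small Step

The source may report more compounds than this note shows. Statements on the series, on what has been measured and on what is new or still open speak of the compounds shown alone.

Compound 2 `COc1cc(-c2cc(/C=C/C(=O)c3ccc(N)cc3)[nH]n2)cc(OC)c1OC` and compound 1 `COc1ccc(-c2cc(/C=C/C(=O)c3ccc(N)cc3)[nH]n2)cc1` share one core and differ only on one aryl ring. In a functional assay on COLO 205 cells (Homo sapiens) for inhibition, read by sulforhodamine B assay, with a stated time of 48 h (a lower number here means a stronger inhibitor of growth, a higher number a weaker inhibitor of growth), compound 2 gives 3340 nM, and compound 1 gives 3450 nM; the two numbers lie within the scatter of each other, so neither can be called the stronger. Compound 3 `COc1ccc(C(=O)/C=C/c2cc(-c3cc(OC)c(OC)c(OC)c3)n[nH]2)cc1` alters compound 2 elsewhere: methoxy in place of amino on an aromatic carbon. Among the measured compounds shown here, no measured pair shows this swap, so the step is expected to be small, at most a slight rise: a 1.2-fold higher number from compound 2 to compound 3 (0.08 log units; within the scatter). Compound 3 is therefore estimated at 4000 nM, with a range from 1500 nM to 11000 nM.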

Compound 3, concentration for total growth inhibition: 3240 nM
Beside the measured number, compound 3's estimate is 1.2-fold (0.09 log units) above it; low and high end bracket the measured number.
By their numbers in this assay, from the lowest: compounds 3, 2 and 1 (each within the scatter of the next).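

In this assay, 4-methoxyphenyl in place of 4-aminophenyl gives a 1.0-fold lower number from compound 2 to compound 3 (0.01 log units; within the scatter) and so leaves no readable difference. Among the compounds shown here, this is the first measured change at this place, on an aromatic carbon para to a large group, since the earlier pair differed only on the other aryl ring. Here, amino and methoxy are not told apart by this read-out, and no supporting data explain that result. Going by these compounds, whether a carboxylic acid or a longer chain such as butoxy at this position would shift the number remains open.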